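A few compounds are considered here, and "the series" means these few. Any claim that something is new, unique, unknown or untested is made for them only; others in the source may bear on it.

Of the compounds shown here, two have so far been tested in a functional assay on MCF7 cells (Homo sapiens) for antiproliferative activity, read by sulforhodamine B assay, with a stated time of 72 h; on this read-out lower numbers stand for stronger inhibition and higher numbers for weaker inhibition. In this assay, compound 1 `COc1ccc(NC(=O)Cn2nc(-c3ccccc3)c3ccccc3c2=O)cc1` gives 77000 nM, and compound 2 `O=C(Cn1nc(Cc2ccccc2)c2ccccc2c1=O)Nc1ccccc1` gives 36000 nM. Compound 2 therefore holds the lower number of the pair, and the gap between the two lies beyond the usual scatter. Both values reflect weak inhibition on this read-out.

The next compound, compound 3 `COc1ccc(NC(=O)Cn2nc(Cc3ccccc3)c3ccccc3c2=O)cc1`, departs from compound 2 by one change on the anilide ring: methoxy in place of hydrogen on an aromatic carbon. The hydrogen para to a large group gives way to methoxy, turning the anilino group into (4-methoxyphenyl)amino. For the measured compounds named here, no measured pair shows this change alone, so the data give no direct size for it. The expectation is therefore a small step at most, not clearly beyond the scatter, with a slight lean towards weaker inhibition. The result is expected to land near the two numbers already in hand. The estimated value for compound 3 is 45000 nM, with an expected range from 18000 nM to 100000 nM. That estimate corresponds to an expected 1.3-fold higher number from compound 2 to compound 3 (0.10 log units; within the scatter).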

Compound 3, half-maximal inhibitory concentration: 62000 nM
Compound 3: the middle estimate sits 1.4-fold (0.14 log units) below what was measured; low and high end bracket the measured number.
By their numbers in this assay, from the lowest: compounds 2, 3 and 1 (each within the scatter of the next, the first and the last beyond it).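

In this assay, the change from anilino to (4-methoxyphenyl)amino, with methoxy in place of hydrogen para to a large group, now has a measured size: a 1.7-fold higher number from compound 2 to compound 3 (0.24 log units; within the scatter), which cannot be told apart from repeat measurement at this position. For the compounds shown here, the new compound also gives the first pair that holds the 4-methoxyphenyl group fixed and changes only the other end of the molecule, with benzyl in place of phenyl on the shared core: a 1.2-fold lower number from compound 1 to compound 3 (0.09 log units; within the scatter), again within the scatter. Taken one at a time, neither change moves the number clearly in this small set, and no measurement at hand says anything about why the steps are this small.

What the compounds leave open is whether any other group at this place on the anilide ring would separate from hydrogen, such as an amine, a carboxylic acid, a hydroxyl or a chlorine. On these data alone, it also remains open whether a longer chain than benzyl, such as 2-phenylethyl, would shift the number on the other side of the core.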